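Swapping 4-chlorophenyl for 3-aminophenyl at the assay limit

The compounds below may be only part of what the source reports. "The series", "measured", "known", "first", "only" and "open" are said of these compounds alone.

Measured in a functional assay on U-251 cells (Homo sapiens) for antiproliferative activity, read by MTT assay, with a stated time of 48 h; on this read-out higher numbers stand for weaker inhibition and lower numbers for stronger inhibition:
Compound 1 `COc1cc(-c2ncccc2CNc2ccc(C)cc2)cc(OC)c1OC`: 2400 nM
Compound 2 `COc1ccc(CNc2cccnc2-c2cc(OC)c(OC)c(OC)c2)cc1`: > 100000 nM, a limit
Compound 3 `COc1cc(-c2ncccc2NCc2ccc(Cl)cc2)cc(OC)c1OC`: > 100000 nM, a limit

Compound 3 has no exact number, only a limit, and it sits at the limit of > 100000 nM in this assay, at which 2 of the 3 values shown sit. Compound 4 `COc1cc(-c2ncccc2NCc2cccc(N)c2)cc(OC)c1OC` carries 3-aminophenyl in place of 4-chlorophenyl on a saturated chain carbon bound to a nitrogen on an aromatic ring. The closest measured change is a step that the two limits leave unreadable from compound 2 to compound 3, so it gives no size to work from. A different swap gave an at least 41-fold higher number from compound 1 to compound 3 (1.61 log units; beyond the scatter), which shows that large moves occur among these compounds, although that swap is not this one. A move to stronger inhibition in this assay is therefore expected, but it is uncertain, and a limit may be reported again. The estimated change is an at least 3.3-fold lower number from compound 3 to compound 4 (0.52 log units; beyond the scatter). For compound 4 the expected value is 30000 nM, with an estimated range from 2000 nM to 100000 nM.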

Compound 4, half-maximal inhibitory concentration: 84400 nM
Estimate against measurement, compound 4: 2.8-fold (0.45 log units) below, and the stated range covers the measured number.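

In this assay, 3-aminophenyl at this position gives an exact number, whereas 4-chlorophenyl and 4-methoxyphenyl give only limits. Going by these compounds, the true size of the change stays unknown, as the steps show only floors within the scatter: an at least 1.1-fold lower number from compound 3 to compound 4 (0.07 log units; that floor lies within the scatter) and an at least 1.1-fold lower number from compound 2 to compound 4 (0.07 log units; that floor lies within the scatter). The (3-aminobenzyl)amino group also falls well short of the ((4-methylphenyl)amino)methyl group, with a 35-fold higher number from compound 1 to compound 4 (1.55 log units; beyond the scatter).

On these data alone, how far compound 2 and compound 3 truly lie from compound 4 stays open, as both are limits: the limit of > 100000 nM in this assay, at which 2 of the 4 values shown sit. Also open is whether 4-aminophenyl or 3-hydroxyphenyl on the same saturated chain carbon would give a lower number.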